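This account rests on a few compounds, and the source may have more. Where it says the series, first, only, none or still open, it means among the compounds named here.

Of the compounds shown here, two that share one core have been tested in a functional assay on OVCAR-3 cells (Homo sapiens) for inhibition, read by sulforhodamine B assay, with a stated time of 48 h, tested at 10 uM; a lower number here means less inhibition, a higher number more inhibition at the concentration tested (going by the name of the read-out). Compound 1 `COc1ccc(-c2cn3ccnc3c(-c3ccc4ncn(C5CCCCC5)c4c3)n2)cc1` is the simpler of the pair, and in this assay compound 1 gives -26.5%, a negative number that amounts to no inhibition at the concentration tested. Compound 2 `c1cn2cc(-c3ccc4c(c3)ncn4C3CCCCC3)nc(-c3ccc4ncn(C5CCCCC5)c4c3)c2n1` carries two cyclohexyl-bearing arms, and in this assay compound 2 gives 3.05%. Compound 2 therefore stands as the higher of the two numbers, its gap to compound 1 lying beyond the usual scatter, although its own value still sits close to no inhibition. Compound 3 `c1ccc(Cn2cnc3ccc(-c4nc(-c5ccc6c(c5)ncn6C5CCCCC5)cn5ccnc45)cc32)cc1` has not yet been measured; it differs from compound 2 in a single place: benzyl in place of cyclohexyl on an aromatic nitrogen. For the measured compounds named here, no comparable step exists among the measured compounds, so the expected step of a number 5 percentage points higher from compound 2 to compound 3 (within the scatter) is small, with no change beyond the scatter expected in either direction. Compound 3 is accordingly estimated at 8%, within a range from -15% to 30%.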

Compound 3, a percentage reported as inhibition, at one concentration (the size of the read-out at that concentration, not a potency): -35.7%
The estimate for compound 3 lay 43.7 percentage points above the measured number; the measured number lies below the stated range.
By their numbers in this assay, from the lowest: compounds 3 and 1 (each within the scatter of the next); then compound 2.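

In this assay, the change on this aromatic nitrogen is not neutral: benzyl in place of cyclohexyl gives a number 38.8 percentage points lower from compound 2 to compound 3 (beyond the scatter). The two groups count alike for hydrogen-bond donors and acceptors, with neither carrying any, and differ by a single heavy atom, so even this modest swap at this position shifts the read-out clearly. The shift does not reveal any inhibition, since compound 2 sits near zero and compound 3 gives -35.7%, a negative number. Nothing available explains why the number falls.

Still open, from the compounds shown here alone, is whether a different group on this nitrogen, such as a short chain ending in an amine or a carboxylic acid, would produce real inhibition. It is also unknown whether benzyl in place of the remaining cyclohexyl would move the number in the same way.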